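This account rests on a few compounds, and the source may have more. Where it says the series, first, only, none or still open, it means among the compounds named here.

In an ADME assay on microsomes from liver (Rattus norvegicus) for metabolic stability, with a stated time of 10 min, tested at 0.5 uM (a higher number here means that more of the compound is left, a lower number that less of the compound is left), compound 1 `Cc1noc(C)c1[C@@H]1C[C@@](C)(c2ccc(F)cc2F)N=C(N)S1` gives 78%. Compound 2 `Cc1noc(C)c1[C@@H]1C[C@@](C)(c2ccc(F)cc2)N=C(N)S1` gives 78%, and compound 3 `Cc1noc(-c2ccc(F)cc2)c1[C@@H]1C[C@@](C)(c2ccc(F)cc2F)N=C(N)S1` gives 88%. Compound 1 therefore stands level with compound 2 and within the scatter of compound 3.

Compound 4 `C[C@@]1(c2ccc(F)cc2F)C[C@@H](c2cncnc2)SC(N)=N1` changes the group on the saturated ring carbon next to the ring sulfur: pyrimidin-5-yl in place of 3,5-dimethyl-1,2-oxazol-4-yl on a saturated ring carbon. Pyrimidin-5-yl replaces 3,5-dimethyl-1,2-oxazol-4-yl there. Among the compounds with values here, no measured step makes this replacement, so the evidence is indirect. Hydrogen in place of fluoro on an aromatic carbon gives no change at the digits printed from compound 1 to compound 2 (within the scatter). This change lies elsewhere in the molecule and is the weaker guide. The closer guide is 4-fluorophenyl in place of methyl on an aromatic carbon, which alters the group now leaving and gives a number 10 percentage points higher from compound 1 to compound 3 (within the scatter). Neither step leaves the scatter, so no shift beyond the scatter is expected, though the direct evidence is thin.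

The expected result in this assay is a number 2 percentage points higher from compound 1 to compound 4 (within the scatter). For compound 4 the estimated value is 80%, with an expected range from 62% to 93%.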

Compound 4, percent of the compound remaining: 95%
The estimate for compound 4 lay 15 percentage points below the measured number; measured number above the stated range.
By their numbers in this assay, from the lowest: compounds 1, 2, 3 and 4 (each within the scatter of the next, the first and the last beyond it).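

The saturated ring carbon next to the ring sulfur is the only place in the series shown where a change leaves the scatter in this assay: pyrimidin-5-yl in place of 3,5-dimethyl-1,2-oxazol-4-yl gives a number 17 percentage points higher from compound 1 to compound 4 (beyond the scatter). The earlier steps shown here, on an aromatic fluoro and on a methyl of the 3,5-dimethyl-1,2-oxazol-4-yl group, stayed within the scatter, and only replacing that whole group moves the number beyond it. Nothing at hand accounts for this step.

Whether the rise needs both ring nitrogens of pyrimidin-5-yl stays open, as no compound shown carries a plain phenyl or a pyridin-3-yl at this position. Within the data shown here, also open is whether the step holds with the single aromatic fluoro of compound 2 in place of the two of compound 1.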